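The source may hold more compounds than are shown below. What is called first, only, known or untested is meant among the compounds shown, and "the series" means these compounds.

Compound 1 `O=S(=O)(/C=C/c1ccc(O)c(O)c1)CC1CCCCC1` gives 7500 nM
Compound 2 `O=S(=O)(/C=C/c1ccc(O)c(O)c1)CCCc1ccccc1` gives 11500 nM

In a functional assay, read by fluorescence and spectrophotometry, with a stated time of 1 h (a higher number here means that more compound is needed for the effect, a lower number that less compound is needed), compound 2 gives 11500 nM, a number within the usual scatter of compound 1 at 7500 nM, so the two cannot be told apart. Compound 3 `C=CCCCCCS(=O)(=O)/C=C/c1ccc(O)c(O)c1` has but-3-en-1-yl in place of phenyl on a saturated chain carbon, three bonds along the chain from a sulfonyl sulfur. Among the measured compounds shown here, no measured pair shows this change directly. For the measured compounds named here, the only guide is that the different side chain of compound 1 at 7500 nM stays within the scatter of compound 2 at 11500 nM. A small change, not beyond the scatter, is therefore expected, and no firm direction can be claimed: the estimated step is a 1.3-fold lower number from compound 2 to compound 3 (0.11 log units; within the scatter). For compound 3 the estimated value is 9000 nM, with an expected range of 3500 nM to 22000 nM.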

Compound 3, half-maximal effective concentration: 7100 nM
Compound 3: the middle estimate sits 1.3-fold (0.10 log units) above what was measured, and the stated range covers the measured number.
By their numbers in this assay, from the lowest: compounds 3, 1 and 2 (each within the scatter of the next).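

In this assay, but-3-en-1-yl in place of phenyl on a saturated chain carbon, three bonds along the chain from a sulfonyl sulfur, gives a 1.6-fold lower number from compound 2 to compound 3 (0.21 log units; within the scatter), so among these compounds an aromatic ring at this position is not required to stay in the same range. Hex-5-en-1-yl in place of cyclohexyl on a saturated chain carbon bound to a sulfonyl sulfur gives a 1.1-fold lower number from compound 1 to compound 3 (0.02 log units; within the scatter), so the open chain also cannot be told apart from the saturated ring. No measurement is available that would explain these results. The compounds shown leave open whether an amine or a carboxylic acid at the end of the chain would move the number beyond the scatter. They also leave open whether the double bond matters, as a fully saturated hexyl chain is not among them.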